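A few compounds are considered here, and "the series" means these few. Any claim that something is new, unique, unknown or untested is made for them only; others in the source may bear on it.

Measured so far:
compound 1 `CCCCOc1ccc(C(O)C2OC(=O)c3c(OC)cc(OC)cc32)cc1` gives 1800 nM in a functional assay on RAW264.7 cells (Mus musculus) for inhibition, read by Griess assay, with stated times of 1 h and 24 h; a lower number here means a stronger inhibitor, a higher number a weaker inhibitor
compound 2 `COCCCOc1ccc(C(O)C2OC(=O)c3c(OC)cc(OC)cc32)cc1` gives 1260 nM in this assay

Among the compounds with values here, compound 2 stands level with compound 1, the only other measured compound, and the two values cannot be told apart. Next is compound 3 `COc1cc(OC)c2c(c1)C(C(O)c1ccc(OCc3ccccc3)cc1)OC2=O`, reached from compound 2 by phenyl in place of 2-methoxyethyl on a saturated chain carbon bound to an oxygen on an aromatic ring on the shared core, that is, phenyl in place of 2-methoxyethyl on a saturated chain carbon bound to an oxygen on an aromatic ring. Within the data shown here, the only measured step on this chain is a 1.4-fold lower number from compound 1 to compound 2 (0.15 log units; within the scatter) and it bears on the change only in part. Among the measured compounds shown here, no measured compound carries a ring on this chain, so the estimate is wide. No step beyond the scatter is expected in this assay and no direction can be given. The expected step is a 1.1-fold higher number from compound 2 to compound 3 (0.05 log units; within the scatter) as an estimate only. For compound 3 the estimated value is 1400 nM (expected range 500 nM to 4000 nM).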

Compound 3, half-maximal inhibitory concentration: > 10000 nM
Compound 3: only a limit was reported; the forecaster's own chance of this, stated with the estimate: 5%; middle value at least 7.1-fold (0.85 log units) away from the limit.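

In this assay phenyl in place of 2-methoxyethyl gives an at least 7.9-fold higher number from compound 2 to compound 3 (0.89 log units; beyond the scatter) and phenyl in place of propyl gives an at least 5.5-fold higher number from compound 1 to compound 3 (0.74 log units; beyond the scatter) at the same place, on a saturated chain carbon bound to an oxygen on an aromatic ring. Within the data shown here, compound 1 and compound 2 could not be told apart, so the open chains alone gave no sign that this position responds to its substituent; benzyloxy is the first group here to move the number beyond the scatter. Compound 3 reads only as a limit, so both steps are minimum sizes and the full extent of the change stays unknown: the limit of > 10000 nM in this assay, at which 1 of the 3 values shown sits.

On these data alone, it remains open whether the aromatic ring itself matters or whether any larger group at this position has the same outcome. A cyclohexylmethyl ether, a longer chain such as hexyl, or an amine at the chain end would help separate these readings.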